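Pentyl to Fluoro on the Aryl Urea: a Small Expected Step

The source may hold more compounds than are shown below. What is called first, only, known or untested is meant among the compounds shown, and "the series" means these compounds.

Measured compounds:
Compound 1, `CCCCCc1ccc(NC(=O)N[C@H](C)c2ccccc2)cc1`: 97%
Compound 2, `CCCCCc1ccc(NC(=O)N[C@@H](C)c2ccccc2)cc1`: 93%
Compound 3, `CCOC(=O)c1ccc(NC(=O)N[C@@H](C)c2ccccc2)cc1`: 92%

In an ADME assay on the whole organism with Oryza sativa as the target, tested at 10 uM (on this read-out lower numbers stand for a stronger effect and higher numbers for a weaker effect at the one concentration tested), compound 1 gives 97%, the highest of the three numbers, yet its two companions lie close: compound 2 sits a number 4 percentage points lower from compound 1 to compound 2 (within the scatter), and compound 3 is another a number 1 percentage points lower from compound 2 to compound 3 (within the scatter) from compound 2. Both steps stay within the scatter, so the three values cannot be ordered. The step from compound 1 to compound 2 rests on (the fact that compounds 1 and 2 differ only in the configuration as drawn), and the step from compound 2 to compound 3 exchanges one group for another on the aromatic carbon of the shared core.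

The next compound is compound 4, `C[C@@H](NC(=O)Nc1ccc(F)cc1)c1ccccc1`, which differs from compound 1 in one place: fluoro in place of pentyl on an aromatic carbon. The step from compound 2 to compound 3 bears on this change most directly, since it also replaces the pentyl group on that aromatic carbon, and it moved the number only within the scatter. Among the compounds with values here, no step among the measured compounds exceeded the scatter at all. Compound 4 is therefore expected to give 93% in this assay, in a range from 80% to 100%. This expectation amounts to a step of a number 4 percentage points lower from compound 1 to compound 4 (within the scatter), which would stay within the scatter.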

Compound 4, a percentage reported as activity, at one concentration (the size of the read-out at that concentration, not a potency): 92%
The estimate for compound 4 lay 1 percentage points above the measured number; measured number inside the range.
By their numbers in this assay, from the lowest: compounds 3, 4, 2 and 1 (each within the scatter of the next).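

In this assay, replacing pentyl with fluoro gives a number 5 percentage points lower from compound 1 to compound 4 (within the scatter) and so adds a much shorter substituent to the picture at this position. On this aromatic carbon, para to a large group, a chain of 5 heavy atoms gives way to 1 fluorine atom, yet the step stays inside the scatter, as did the earlier exchange of pentyl for ethoxycarbonyl. The earlier compounds had shown this position only with multi-atom groups, whereas compound 4 shows that shortening the substituent to a single atom does not move the read-out beyond the scatter either, and nothing on hand bears on the reason for this.

Within the data shown here, since every step so far stays within the scatter, it remains open whether any group on this aromatic carbon can move the number beyond it, for example an amine, a carboxylic acid or a chain longer than pentyl. As far as these compounds go, it is also open whether fluoro would behave the same way with the other drawn configuration, or whether a change elsewhere on the shared core, such as a methoxy group on the second aromatic ring, would shift the read-out.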